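The source may report more compounds than this note shows. Statements on the series, on what has been measured and on what is new or still open speak of the compounds shown alone.

Compound 1 `CCC(C(=O)N1CCN(c2cccc(F)c2)CC1)N1C(=O)CCC1=O`: 75%
Compound 2 `CCC(C(=O)N1CCN(c2cccc(C)c2)CC1)N1C(=O)CCC1=O`: 100%

In a functional assay on the whole organism (strain Swiss) with Mus musculus as the target, in the maximal electroshock model, with a stated time of 0.25 h, at a dose of 300 mg/kg by the intraperitoneal route (a lower number here means a weaker effect, a higher number a stronger effect of the compound at the dose given), compound 2 gives 100%, the highest of the two numbers; compound 1 stands a step below it, as a number 25 percentage points higher from compound 1 to compound 2 (beyond the scatter) shows. Compound 3 `CCC(C(=O)N1CCN(c2cccc(Cl)c2)CC1)N1C(=O)CCC1=O` differs from compound 2 in one place: chloro in place of methyl on an aromatic carbon. Among the measured compounds shown here, no measured step exchanges methyl for chloro, so only the fluoro-to-methyl step of compound 1 gives a sense of how much a change at this position can move the read-out. The result of compound 3 is therefore expected near that of compound 2, with a step of a number 10 percentage points lower from compound 2 to compound 3 (within the scatter) anticipated. Compound 3 is estimated at 90%, between 65% and 100%.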

Compound 3, a percentage reported as activity, at one dose (the size of the read-out at that dose, not a potency): 75%
For compound 3 the middle estimate is 15 percentage points above the measured one, and the stated range covers the measured number.
By their numbers in this assay, from the lowest: compounds 1 and 3 (each within the scatter of the next); then compound 2.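

In this assay, chloro did not hold the read-out reached with methyl at this position, giving a number 25 percentage points lower from compound 2 to compound 3 (beyond the scatter). Exchanging one halogen for the other gave no change at the digits printed from compound 1 to compound 3 (within the scatter), so among the three compounds the 3-methylphenyl group alone stands apart, with both halogens reading alike. Nothing available accounts for this difference. Whether methyl is special or any carbon group would serve stays open, as neither an ethyl nor a methoxy group is among the compounds shown. An amine at this place is equally untested here.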